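Pyrazolone amides: aryl change on the ring nitrogen

The source may hold more compounds than are shown below. What is called first, only, known or untested is meant among the compounds shown, and "the series" means these compounds.

Measured so far:
compound 1 `Cc1cc(=O)n(-c2cccc(F)c2)nc1C(=O)Nc1ccc(Oc2ncnc3[nH]ccc23)c(F)c1` — 31500 nM
compound 2 `Cc1ccc(-n2nc(C(=O)Nc3ccc(Oc4ncnc5[nH]ccc45)c(F)c3)c(C)cc2=O)cc1` — 18500 nM

In a functional assay on A549 cells (Homo sapiens) for cytotoxicity, read by MTT assay, with a stated time of 72 h (on this read-out higher numbers stand for weaker inhibition and lower numbers for stronger inhibition), compound 2 gives 18500 nM. Within the data shown here, its only neighbour is compound 1, and the step of a 1.7-fold lower number from compound 1 to compound 2 (0.23 log units; within the scatter) leaves the two within the scatter of each other. Compound 3 `Cc1cc(=O)n(-c2ccc(Br)cc2F)nc1C(=O)Nc1ccc(Oc2ncnc3[nH]ccc23)c(F)c1` carries 4-bromo-2-fluorophenyl in place of 4-methylphenyl on an aromatic nitrogen. Among the measured compounds shown here, the one measured step that bears on a change at this position, a 1.7-fold lower number from compound 1 to compound 2 (0.23 log units; within the scatter), did not move the number beyond the scatter, so no shift beyond the scatter is expected in this assay here either. Compound 3 is therefore estimated at 22000 nM, from 8000 nM to 60000 nM, an expected step of a 1.2-fold higher number from compound 2 to compound 3 (0.08 log units; within the scatter).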

Compound 3, half-maximal inhibitory concentration: 6120 nM
Compound 3: middle estimate off by 3.6-fold (0.56 log units), on the high side, outside the stated range (below it).
By their numbers in this assay, from the lowest: compound 3; then compounds 2 and 1 (each within the scatter of the next).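

The aryl group on the aromatic nitrogen can move the number in this assay beyond the scatter, which the earlier change at this position did not do. 4-Bromo-2-fluorophenyl gives this shift against both earlier aryl groups (a 3.0-fold lower number from compound 2 to compound 3 (0.48 log units; beyond the scatter); a 5.1-fold lower number from compound 1 to compound 3 (0.71 log units; beyond the scatter)), though both steps are modest. Nothing on hand accounts for these steps.

Since 4-bromo-2-fluorophenyl brings both halogens together, the compounds shown do not separate the share of the bromine from that of the fluorine. Going by these compounds, how an aryl group carrying an amine or a carboxylic acid would read here remains open.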